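Ethyl ester to free acid across two related cores

A few compounds are considered here, and "the series" means these few. Any claim that something is new, unique, unknown or untested is made for them only; others in the source may bear on it.

Compound 1 `CCOC(=O)c1cc(-c2cc(OC)c(OC)c(OC)c2)c(-c2ccc(OC)c(O)c2)s1` and compound 3 `CCOC(=O)c1cc(-c2ccc(OC)cc2)c(-c2cc(OC)c(OC)c(OC)c2)s1` carry the same ethoxycarbonyl group on cores that differ in more than one place; the difference between the two cores is not broken down here. In a functional assay on KB cells (Homo sapiens) for antiproliferative activity, read by MTT assay, with a stated time of 72 h (on this read-out higher numbers stand for weaker inhibition and lower numbers for stronger inhibition), compound 1 gives 1250 nM, and compound 3 gives 10200 nM. Compound 2 `COc1ccc(-c2sc(C(=O)O)cc2-c2cc(OC)c(OC)c(OC)c2)cc1O` differs from compound 1 by hydrogen in place of ethyl on an oxygen next to a carbonyl group; in this assay compound 2 gives 11200 nM, the step being a 9.0-fold higher number from compound 1 to compound 2 (0.95 log units; beyond the scatter). Compound 4 `COc1ccc(-c2cc(C(=O)O)sc2-c2cc(OC)c(OC)c(OC)c2)cc1` differs from compound 3 by the same change, (hydrogen in place of ethyl on an oxygen next to a carbonyl group). Going by the values given here, with the earlier step of a 9.0-fold higher number from compound 1 to compound 2 (0.95 log units; beyond the scatter) as the only precedent, the estimated step is a 5.9-fold higher number from compound 3 to compound 4 (0.77 log units; beyond the scatter). Compound 4 is therefore expected to give about 60000 nM, with the estimate spanning 20000 nM to 150000 nM.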

Compound 4, half-maximal inhibitory concentration: 8650 nM
Compound 4: the middle estimate sits 6.9-fold (0.84 log units) above what was measured, outside the stated range (below it).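

In this assay the change from ethoxycarbonyl to carboxy on the core of compound 3 gives a 1.2-fold lower number from compound 3 to compound 4 (0.07 log units; within the scatter), so the loss seen on the core of compound 1 does not recur here. The size of this change therefore does not carry from one core to the other in this series: the same change on two cores in this assay, a 9.0-fold higher number (0.95 log units; beyond the scatter) from compound 1 to compound 2 and a 1.2-fold lower number (0.07 log units; within the scatter) from compound 3 to compound 4, 11-fold (1.02 log units) apart, beyond the scatter of two such steps

Going by these compounds alone, with only two pairs, this shows that the step varies with the core, but it gives no rule for any further core.

Still open is which single difference between the two cores separates the two steps, as no pair shown isolates one. Also open, on these data alone, is how a methyl ester or a primary amide in place of the ethoxycarbonyl group would behave on either core.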